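Swapping a methoxy for a methyl on a benzyl ether

A few compounds are considered here, and "the series" means these few. Any claim that something is new, unique, unknown or untested is made for them only; others in the source may bear on it.

Measured compounds:
- compound 1, `N#CCCn1nc(-c2ccc(OCc3ccccc3)cc2)oc1=O`: 2.2 nM
- compound 2, `N#CCCn1nc(-c2ccc(OCc3ccc([N+](=O)[O-])cc3)cc2)oc1=O`: 5500 nM
- compound 3, `COc1cccc(COc2ccc(-c3nn(CCC#N)c(=S)o3)cc2)c1`: 100 nM

Of the compounds shown here, three have been tested in an assay for inhibition of Amine oxidase [flavin-containing] B (Rattus norvegicus); a higher number here means a weaker inhibitor, a lower number a stronger inhibitor. Compound 1 `N#CCCn1nc(-c2ccc(OCc3ccccc3)cc2)oc1=O` gives 2.2 nM, compound 2 `N#CCCn1nc(-c2ccc(OCc3ccc([N+](=O)[O-])cc3)cc2)oc1=O` gives 5500 nM, and compound 3 `COc1cccc(COc2ccc(-c3nn(CCC#N)c(=S)o3)cc2)c1` gives 100 nM. Compound 3 therefore has the second highest of the three numbers: its nearest neighbour is compound 1, which gives a number that is lower, and its furthest is compound 2, which gives a number that is higher.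

The next compound, compound 4 `Cc1cccc(COc2ccc(-c3nn(CCC#N)c(=S)o3)cc2)c1`, differs from compound 3 in one place: methyl in place of methoxy on an aromatic carbon. Among the compounds with values here, no measured step covers this kind of change. Within the data shown here, the only step recorded, a 2500-fold higher number from compound 1 to compound 2 (3.40 log units; beyond the scatter), concerns a different substituent at a different position, so it gives no direct guide; it only shows that a single change on the benzyl ring can shift the number a great deal. With nothing closer to go on, the expectation for compound 4 in this assay is a number near that of compound 3, with the step of no change at the digits printed from compound 3 to compound 4 (within the scatter) expected to stay within the scatter. Compound 4 is thus estimated at 100 nM, within a range of 30 nM to 350 nM.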

Compound 4, half-maximal inhibitory concentration: 66 nM
For compound 4 the middle estimate is 1.5-fold (0.18 log units) above the measured one, within the range that was stated.
By their numbers in this assay, from the lowest: compound 1; then compounds 4 and 3 (each within the scatter of the next); then compound 2.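

In this assay, the change from 3-methoxyphenyl to 3-methylphenyl gives a 1.5-fold lower number from compound 3 to compound 4 (0.18 log units; within the scatter) and so leaves the number effectively unmoved. The earlier step, a 2500-fold higher number from compound 1 to compound 2 (3.40 log units; beyond the scatter), showed that one new group on the benzyl ring can matter enormously; this pair shows that at this place, a methoxy can give way to a methyl, with one heavy atom and one hydrogen-bond acceptor fewer, without a change beyond the scatter. No measurement shown here explains why these two groups read alike.

Open, as far as these compounds go, is how an amine or a carboxylic acid at this same place would read in this assay, and whether such groups would stay as close as methoxy and methyl do. Also open, from the compounds shown here alone, is whether a longer chain, such as an ethyl or a propyl, would be accommodated equally well.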